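Methylamino for hexylsulfanyl on the core of compound 1

The compounds below may be only part of what the source reports. "The series", "measured", "known", "first", "only" and "open" are said of these compounds alone.

Compound 1 `CCCCCCSc1nc(N)nc2c1ncn2/C=C1/CC1(CO)CO` is the reference point in an ADME assay on Akata cells (Homo sapiens) for cytotoxicity, with a stated time of 7 days; a lower number here means that less compound is tolerated, a higher number that more compound is tolerated. In this assay compound 1 gives only a limit, > 20000 nM. Compound 2 `Nc1nc2c(ncn2/C=C2/CC2(CO)CO)c(=O)[nH]1` likewise gives only a limit, > 20000 nM. Compound 3 `CCCCOc1nc(N)nc2c1ncn2/C=C1/CC1(CO)CO` also gives only a limit, > 20000 nM. Among the measured compounds shown here, the one step that touches the same carbon, a step that the two limits leave unreadable from compound 1 to compound 3, is therefore unreadable, because every value sits at the limit of > 20000 nM in this assay, at which 3 of the 3 values shown sit. Compound 4 `CNc1nc(N)nc2c1ncn2/C=C1/CC1(CO)CO` differs from compound 1 by methylamino in place of hexylsulfanyl on an aromatic carbon. No readable step bears on this change, so no shift beyond the scatter can be expected in either direction. For compound 4 the estimate is 30000 nM, with a range from 15000 nM to 80000 nM, most likely reported again as a limit. The expected step that the limit leaves unreadable from compound 1 to compound 4 is thus essentially flat.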

Compound 4, half-maximal cytotoxic concentration: > 24000 nM
Compound 4: only a limit was reported; the forecaster's own chance of this, stated with the estimate: 85%; the middle value does not contradict the limit.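

Among the compounds shown here, compound 1, compound 3 and compound 4 each give only a limit in this assay, and no step among them can be read. From the compounds shown here alone, whether any substituent at this carbon of the shared core changes tolerated concentration remains open.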